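The source may report more compounds than this note shows. Statements on the series, on what has been measured and on what is new or still open speak of the compounds shown alone.

Measured in an in vitro ADME assay on microsomes from liver (Homo sapiens) for metabolic stability, tested at 5 uM; a lower number here means that the compound disappears faster, a higher number that the compound lasts longer:
- Compound 1 `CC(C)CCn1nc(-c2cccs2)c(O)c(C2=NS(=O)(=O)c3cc(S(C)(=O)=O)ccc3N2)c1=O` gives 0.0933 h.
- Compound 2 `CC(C)CCn1nc(C2CCCCC2)c(O)c(C2=NS(=O)(=O)c3cc(NS(C)(=O)=O)ccc3N2)c1=O` gives 0.117 h.
- Compound 3 `CCC(C)(C)Cn1nc(-c2cccs2)c(O)c(C2=NS(=O)(=O)c3cc(NS(C)(=O)=O)ccc3N2)c1=O` is reported only as a limit, > 1 h.

Compound 3 thus stands at the limit of this assay, and that limit is described by the limit of > 1 h in this assay, at which 1 of the 3 values shown sits; of the three values shown, only compound 3 sits there, while compound 1 and compound 2 lie far from it. How far compound 3 in fact lasts beyond that limit is not known.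

Compound 4 `CS(=O)(=O)Nc1ccc2c(c1)S(=O)(=O)N=C(c1c(O)c(-c3cccs3)nn(Cc3ccccn3)c1=O)N2` has not yet been measured. It differs from compound 3 in one place: pyridin-2-yl in place of 1,1-dimethylpropyl on a saturated chain carbon bound to an aromatic nitrogen

Among the compounds with values here, no pair of measured compounds differing in a single place is available, so no measured step guides the expectation. Because compound 3 gives > 1 h only as a limit, the direction of the change toward compound 4 can only be guessed, and a moderate decrease in this assay is expected, as an at least 2.0-fold lower number from compound 3 to compound 4 (0.30 log units; that floor lies within the scatter). For compound 4 a half-life of 0.5 h is estimated, within a range from 0.15 h to 1.5 h.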

Compound 4, half-life: > 1 h
Compound 4 was reported as a limit (the forecaster's own chance of this, stated with the estimate: 25%); middle value at least 2.0-fold (0.30 log units) away from the limit.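

Within the data shown here, compound 3 and compound 4 are both reported in this assay only as limits, so no step between them can be read: the limit of > 1 h in this assay, at which 2 of the 4 values shown sit. The compounds shown leave open how long either one lasts beyond that limit and which lasts longer.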